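Side chains on the amide-type nitrogen: working notes

A few compounds are considered here, and "the series" means these few. Any claim that something is new, unique, unknown or untested is made for them only; others in the source may bear on it.

- Compound 1 `CCn1c(C(=O)N[C@@H](C)C(=O)OC)ccc1C(CC)(CC)c1ccc(OCS(=O)(=O)c2ccccc2)c(C)c1` gives 43700 nM
- Compound 2 `CCn1c(C(=O)N[C@H](CO)CCCO)ccc1C(CC)(CC)c1ccc(OCS(=O)(=O)c2ccccc2)c(C)c1` gives 31400 nM
- Compound 3 `CCn1c(C(=O)N[C@@H](C)C(=O)O)ccc1C(CC)(CC)c1ccc(OCS(=O)(=O)c2ccccc2)c(C)c1` is not yet measured

In a functional assay on MCF7 cells (Homo sapiens) for antiproliferative activity, read by MTT assay, with a stated time of 24 h (on this read-out higher numbers stand for weaker inhibition and lower numbers for stronger inhibition), compound 2 gives 31400 nM and stands level with compound 1 within the scatter. Compound 3 carries a 1-carboxyethyl group on the amide-type nitrogen (a group of 5 heavy atoms (3 carbon, 2 oxygen; no ring) in place of a group of 7 heavy atoms (5 carbon, 2 oxygen; no ring), on an amide-type nitrogen). Going by the values given here, the one measured step at this nitrogen (a 1.4-fold lower number from compound 1 to compound 2 (0.14 log units; within the scatter)) stayed within the scatter, so no step beyond the scatter is expected in this assay here. The estimated step is a 1.3-fold higher number from compound 2 to compound 3 (0.11 log units; within the scatter) on this read-out. For compound 3 the expected value is 40000 nM with an estimated range of 20000 nM to 80000 nM on this read-out.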

Compound 3, half-maximal inhibitory concentration: 35500 nM
Compound 3: middle estimate off by 1.1-fold (0.05 log units), on the high side; the measured number falls inside the stated range.
By their numbers in this assay, from the lowest: compounds 2, 3 and 1 (each within the scatter of the next).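

In this assay, the 1-carboxyethyl group on the amide-type nitrogen adds a second step within the scatter (a 1.1-fold higher number from compound 2 to compound 3 (0.05 log units; within the scatter)), and hydrogen in place of methyl on an oxygen next to a carbonyl group also stays within it (a 1.2-fold lower number from compound 1 to compound 3 (0.09 log units; within the scatter)). Across compounds 1, 2 and 3, this position therefore shows no step beyond the scatter, even with the ester changed to the free carboxylic acid. No measurement bears on why these numbers stay level.

From the compounds shown here alone, whether an amine or a phenyl ring on this nitrogen would move the number beyond the scatter remains open. Going by these compounds, the mirror-image form of the 1-carboxyethyl group also remains open.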